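Replacing a Ring Substituent on the Quinone-Like Core with a Chain

A few compounds are considered here, and "the series" means these few. Any claim that something is new, unique, unknown or untested is made for them only; others in the source may bear on it.

Among the compounds with values here, compound 3, `CC1=C(N2CC2)C(=O)C(N2CC2)=C(N2CC2)C1=O`, is the most potent of the three compounds measured so far in a functional assay on L1210 cells (Mus musculus), with a stated time of 12 days (a lower number here means a less potent compound, a higher number a more potent compound, by a factor of ten per unit of this negative logarithm), where compound 3 gives 6.21. Its nearest neighbour is compound 2, `CCC(COC(N)=O)C1=C(N2CC2)C(=O)C(C)=C(N2CC2)C1=O`, which in this assay gives 5.66, and the furthest is compound 1, `COCCC1=C(N2CC2)C(=O)C(C)=C(N2CC2)C1=O`, which gives 5.42; both of those gaps lie beyond the usual scatter.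

The next compound, compound 4, `CCC(OC)C1=C(N2CC2)C(=O)C(C)=C(N2CC2)C1=O`, is made from compound 3 by one change: 1-methoxypropyl in place of aziridin-1-yl on a double-bonded ring carbon. Within the data shown here, the only measured step that speaks to this is the one from compound 1 to compound 3, a number 0.79 log units higher from compound 1 to compound 3 (beyond the scatter), where a chain with an oxygen in it gave way to the three-membered ring and the number rose. Compound 4 reverses that kind of exchange, putting a chain back in the place of the ring, so a drop of roughly the same size is the natural expectation, and compound 2, a chain-bearing relative, sits in the same region. The step from compound 3 to compound 4 is therefore expected to be a number 0.61 log units lower from compound 3 to compound 4 (beyond the scatter). Compound 4 is estimated to give 5.6 in this assay, with a likely range from 5.2 to 6.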

Compound 4, logarithm of the reciprocal of the active concentration, log(1/C): 5.33
Compound 4: the middle estimate sits 0.27 log units above what was measured; the range from low to high includes it.
By their numbers in this assay, from the lowest: compounds 4, 1 and 2 (each within the scatter of the next, the first and the last beyond it); then compound 3.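

In this assay, putting 1-methoxypropyl in place of aziridin-1-yl on this double-bonded ring carbon gives a number 0.88 log units lower from compound 3 to compound 4 (beyond the scatter), so the second chain tested here also falls short of the three-membered ring. The two chains themselves cannot be told apart at this carbon: 1-methoxypropyl in place of 2-methoxyethyl gives a number 0.09 log units lower from compound 1 to compound 4 (within the scatter), which means that these two chains, which both carry a methoxy group, give the same result in practice. Further out on the chain, the end group does register, if modestly, since methoxy in place of (carbamoyloxy)methyl gives a number 0.33 log units lower from compound 2 to compound 4 (beyond the scatter), so the chain-bearing compounds are not all equivalent.

Nothing measured here says why the three-membered ring and the chains differ. From the compounds shown here alone, it also remains open whether another nitrogen group on this carbon, such as the four-membered azetidin-1-yl ring or an open-chain dimethylamino group, would stay close to compound 3 at 6.21 or fall to the level of the chains.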